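Cytotoxicity notes on a biaryl amide series

The compounds below may be only part of what the source reports. "The series", "measured", "known", "first", "only" and "open" are said of these compounds alone.

Measured so far:
compound 1 `Cc1nnc(-c2cccc(-c3ccc(C(=O)N(Cc4cccc(OCCCCCC(=O)O)c4)C(C)C)cc3)c2)o1` — > 26000 nM
compound 2 `CCOC(=O)CCCCCOc1cccc(CN(C(=O)c2ccc(-c3cccc(OC(C)C)c3)cc2)C(C)C)c1` — > 26000 nM

In an ADME assay on BJ cells (Homo sapiens) for cytotoxicity, read by CellTiter-Glo and resazurin assay, with a stated time of 72 h (on this read-out higher numbers stand for an effect only at larger amounts of compound and lower numbers for an effect already at smaller amounts), compound 1 gives > 26000 nM, which is a limit of the assay rather than a number. Compound 2 in this assay likewise reaches only a limit, > 26000 nM. Compound 2 therefore stands exactly where compound 1 stands: both values shown in this assay are limits, and no order can be drawn between them, as the limit of > 26000 nM in this assay, at which 2 of the 2 values shown sit, records.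

Compound 3 `CCOC(=O)CCCCCOc1cccc(CN(C(=O)c2ccc(-c3cccc(-c4nnc(C)o4)c3)cc2)C(C)C)c1` differs from compound 2 by 5-methyl-1,3,4-oxadiazol-2-yl in place of isopropoxy on an aromatic carbon. Among the measured compounds shown here, no measured pair in this assay shows what such a change does, so no size or direction of step can be read from the data. For the measured compounds named here, since every value shown in this assay is a limit and no compound in the set has given a number, the expectation for the step from compound 2 to compound 3 is none beyond the scatter, a step that the limit leaves unreadable from compound 2 to compound 3, with the likely outcome again a limit. On that basis compound 3 is estimated in this assay at 30000 nM, with a range from 15000 nM to 60000 nM.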

Compound 3, half-maximal effective concentration: > 26000 nM
Compound 3 ended at the assay's limit; the forecaster's own chance of this, stated with the estimate: 80%; the middle value does not contradict the limit.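

Compound 3 sits at a limit of the assay, as do compound 1 and compound 2, so no step can be read between compound 3 and either of them in this assay: the limit of > 26000 nM in this assay, at which 3 of the 3 values shown sit.

The compounds shown leave open whether any change to the shared core would bring a value in this assay inside the range of the assay.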